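A few compounds are considered here, and "the series" means these few. Any claim that something is new, unique, unknown or untested is made for them only; others in the source may bear on it.

Compound 1 `COc1cccc(C(=O)N/N=C/C2=C(Cl)c3cc(C)c(C)cc3CCC2)c1C` and compound 2 `Cc1cc2c(cc1C)C(Cl)=C(/C=N/NC(=O)c1ccccc1N)CCC2` share one core and differ only in the aryl group on the carbonyl carbon. In a functional assay on HeLa cells (Homo sapiens) for inhibition, read by sulforhodamine B assay, with a stated time of 48 h (a higher number here means a weaker inhibitor of growth, a lower number a stronger inhibitor of growth), compound 1 gives 300 nM. For compound 2 this assay reports only a limit, > 100000 nM, so where compound 2 truly stands is not known (the limit of > 100000 nM in this assay, at which 1 of the 2 values shown sits). Within the data shown here, the single measured step, an at least 330-fold higher number from compound 1 to compound 2 (2.52 log units; beyond the scatter), shows that the group on the carbonyl carbon can move the number a long way. Compound 3 `Cc1cc2c(cc1C)C(Cl)=C(/C=N/NC(=O)c1cccnc1)CCC2` carries the change (pyridin-3-yl in place of 2-aminophenyl on a carbonyl carbon). Among the measured compounds shown here, no measured step covers this exchange: compound 2 sits at a limit, while compound 1 shows that another aryl group at that place reaches a far lower number. In this assay the expected step is an at least 5.0-fold lower number from compound 2 to compound 3 (0.69 log units; beyond the scatter), downward but of very uncertain size. Compound 3 is therefore estimated at 20000 nM, with a range from 1500 nM to 100000 nM.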

Compound 3, concentration for 50% growth inhibition: 650 nM
Beside the measured number, compound 3's estimate is 31-fold (1.49 log units) above it, and the stated range ends above it.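

In this assay the exchange on the carbonyl carbon gives an at least 150-fold lower number from compound 2 to compound 3 (2.18 log units; beyond the scatter) and shows that a ring with a hetero atom at this place can reach a low number. The pyridin-3-yl group also stays close to the 3-methoxy-2-methylphenyl group, with a 2.2-fold higher number from compound 1 to compound 3 (0.34 log units; beyond the scatter) as only a modest step, so among the three groups shown, the 2-aminophenyl group of compound 2 is the one that stands apart. From the compounds shown here alone, the size of the first step remains open-ended, as compound 2 is known only through a limit: the limit of > 100000 nM in this assay, at which 1 of the 3 values shown sits.

Going by these compounds, whether that limit goes with the amine or with the carbon-only ring that carries it stays open, and a plain phenyl group on the carbonyl carbon would help to separate the two. Also open, on these data alone, is whether the place of the ring nitrogen matters, which a pyridin-4-yl group would test.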